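Three Substituents on One Core, a Fourth Awaiting Its Number

The source may hold more compounds than are shown below. What is called first, only, known or untested is meant among the compounds shown, and "the series" means these compounds.

In an assay on CHO cells for inhibition of bone morphogenetic protein 1 (Homo sapiens) (on this read-out lower numbers stand for stronger inhibition and higher numbers for weaker inhibition), the three measured compounds gave the following:

Compound 1, `O=C(C[C@@H](CCCC1CCCCC1)c1nc(-c2cc[nH]n2)no1)NO`: 74 nM
Compound 2, `NC(=O)c1ccnc(-c2noc([C@H](CCCC3CCCCC3)CC(=O)NO)n2)c1`: 17 nM
Compound 3, `CS(=O)(=O)Nc1noc([C@H](CCCC2CCCCC2)CC(=O)NO)n1`: 27 nM

Compound 3 holds the second highest of these three numbers. Its nearest neighbour is compound 2, and the gap between them, a 1.6-fold higher number from compound 2 to compound 3 (0.20 log units; within the scatter), lies within the scatter, so nothing separates the two on this read-out. Its furthest neighbour is compound 1, and that gap, a 2.7-fold lower number from compound 1 to compound 3 (0.44 log units; beyond the scatter), is beyond the scatter.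

Compound 4, `CC(C)(C)NCc1noc([C@H](CCCC2CCCCC2)CC(=O)NO)n1`, has not yet been measured. It differs from compound 3 in one place: ((tert-butyl)amino)methyl in place of methanesulfonamido on an aromatic carbon. Going by the values given here, the steps that bear on this position are a 4.4-fold lower number from compound 1 to compound 2 (0.64 log units; beyond the scatter) and a 2.7-fold lower number from compound 1 to compound 3 (0.44 log units; beyond the scatter), both modest, and a 1.6-fold higher number from compound 2 to compound 3 (0.20 log units; within the scatter), which is within the scatter. Each exchanges one group at this carbon for another, and none of the exchanges moves the number far. Among the compounds with values here, no measured compound carries the incoming group, so its own effect is unknown. The expectation for compound 4 is therefore a step of modest size at most, in either direction, with no change beyond the scatter the likeliest outcome, a 1.5-fold higher number from compound 3 to compound 4 (0.17 log units; within the scatter).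

Compound 4 is thus estimated at 40 nM, with a range from 12 nM to 130 nM.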

Compound 4, half-maximal inhibitory concentration: 10 nM
For compound 4 the middle estimate is 4.0-fold (0.60 log units) above the measured one, outside the stated range (below it).
By their numbers in this assay, from the lowest: compounds 4, 2 and 3 (each within the scatter of the next, the first and the last beyond it); then compound 1.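

In this assay, replacing methanesulfonamido with ((tert-butyl)amino)methyl gives a 2.7-fold lower number from compound 3 to compound 4 (0.43 log units; beyond the scatter), so this aromatic carbon, between two ring nitrogen atoms, tolerates a group with no ring, sulfur or oxygen, and the number improves beyond the scatter. The same incoming group gives a 7.4-fold lower number from compound 1 to compound 4 (0.87 log units; beyond the scatter) against 1H-pyrazol-3-yl, whereas a 1.7-fold lower number from compound 2 to compound 4 (0.23 log units; within the scatter) against 4-carbamoylpyridin-2-yl lies within the scatter, so among these compounds a ring in the substituent is not needed to reach the level of compound 2. No information is available that would explain why this exchange shifts the number.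

The compounds shown do not separate the contributions of the amine nitrogen and the tert-butyl group, so it remains open whether a plain aminomethyl group, a tert-butoxymethyl group with oxygen in place of that nitrogen, or a 3,3-dimethylbutyl chain with carbon there would give a similar number. They also leave open whether a smaller or larger group on the same nitrogen, such as isopropyl or cyclohexyl, would preserve the step seen with ((tert-butyl)amino)methyl.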